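Hydroxyethyl Amide to Anilide: An Expected Drop in Tolerance

A few compounds are considered here, and "the series" means these few. Any claim that something is new, unique, unknown or untested is made for them only; others in the source may bear on it.

Compound 3 `O=C(NCCO)c1cccc2[nH]c(-c3ccncc3)nc12` gives 498 uM in an ADME assay on Vero cells (Chlorocebus sabaeus) for cytotoxicity (a higher number here means that more compound is tolerated, a lower number that less compound is tolerated), the highest of the three numbers in hand. Compound 2 `O=C(Nc1ccccc1)c1cccc2[nH]c(-c3cccnc3)nc12` gives 34.2 uM and compound 1 `O=C(Nc1ccccc1)c1cccc2[nH]c(-c3ccccn3)nc12` gives 17.9 uM; both sit beyond the scatter below compound 3. Going by the values given here, the only measured step, a 1.9-fold higher number from compound 1 to compound 2 (0.28 log units; within the scatter), concerns the pyridinyl group on the shared core and not the amide-type nitrogen. Compound 4 `O=C(Nc1ccccc1)c1cccc2[nH]c(-c3ccncc3)nc12` arises from compound 3 by phenyl in place of 2-hydroxyethyl on an amide-type nitrogen. Among the compounds with values here, no measured step bears directly on this change; what the data show is that compounds 1 and 2, which both carry the anilide, lie far below compound 3. A large step down is therefore expected, a 17-fold lower number from compound 3 to compound 4 (1.22 log units; beyond the scatter). Compound 4 is estimated at 30 uM, within 10 uM to 100 uM.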

Compound 4, half-maximal toxic concentration: 49.8 uM
Compound 4: middle estimate off by 1.7-fold (0.22 log units), on the low side; low and high end bracket the measured number.
By their numbers in this assay, from the lowest: compounds 1, 2 and 4 (each within the scatter of the next, the first and the last beyond it); then compound 3.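

Measured in this assay, phenyl in place of 2-hydroxyethyl on an amide-type nitrogen now has a direct reading at this position (a 10-fold lower number from compound 3 to compound 4 (1.00 log units; beyond the scatter)). With the anilide held fixed, the pyridinyl comparison gains a third member: pyridin-4-yl against pyridin-3-yl stays within the scatter (a 1.5-fold higher number from compound 2 to compound 4 (0.16 log units; within the scatter)), while pyridin-4-yl against pyridin-2-yl goes beyond it (a 2.8-fold higher number from compound 1 to compound 4 (0.44 log units; beyond the scatter)). No evidence at hand explains either kind of change.

Going by these compounds, whether an amine, a carboxylic acid or a longer chain on that nitrogen would stay close to compound 3 remains open. So does whether the pyridinyl steps seen among the anilides carry over to the 2-hydroxyethyl amides.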